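Swapping a Chlorophenyl for a Pyrimidine Ring

The source may hold more compounds than are shown below. What is called first, only, known or untested is meant among the compounds shown, and "the series" means these compounds.

Two compounds share one fused two-ring core, compound 1 `CO[C@@H]1CC=C2NN(c3cc(Cl)cc(Cl)c3)C(=O)C[C@]2(C)O1` and compound 2 `CO[C@@H]1CC=C2NN(c3ccc(Cl)cc3)C(=O)C[C@]2(C)O1`. In a functional assay on DU-145 cells (Homo sapiens) for inhibition, read by sulforhodamine B assay, with a stated time of 48 h (on this read-out lower numbers stand for stronger inhibition and higher numbers for weaker inhibition), compound 1 gives 21300 nM, and compound 2 gives 24200 nM, the highest of the two numbers, though the difference from compound 1 lies within the scatter. Compound 3 `CO[C@@H]1CC=C2NN(c3cncnc3)C(=O)C[C@]2(C)O1` differs from compound 2 by pyrimidin-5-yl in place of 4-chlorophenyl on an amide-type nitrogen in a ring. Among the compounds with values here, no measured pair shows this change, so the expectation rests on little; a modest shift toward a higher number is expected, a 1.7-fold higher number from compound 2 to compound 3 (0.22 log units; within the scatter). Compound 3 is thus estimated at 40000 nM, within 15000 nM to 100000 nM.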

Compound 3, half-maximal inhibitory concentration: 17100 nM
For compound 3 the middle estimate is 2.3-fold (0.37 log units) above the measured one; the range from low to high includes it.
By their numbers in this assay, from the lowest: compounds 3, 1 and 2 (each within the scatter of the next).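

In this assay, pyrimidin-5-yl in place of 4-chlorophenyl gives a 1.4-fold lower number from compound 2 to compound 3 (0.15 log units; within the scatter). On the amide-type nitrogen, then, a ring with 2 hetero atoms and no chlorine can stand in for a ring of carbon only without moving the number beyond the scatter, so in these compounds this position shows no need for the chlorine or for an all-carbon ring. Nothing available explains this result. Still open, from the compounds shown here alone, is whether a group of another kind here, such as an amine, a carboxylic acid or a longer chain, would shift the number beyond the scatter.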